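The source may report more compounds than this note shows. Statements on the series, on what has been measured and on what is new or still open speak of the compounds shown alone.

Measured so far in a functional assay on HL-60 cells (Homo sapiens) for cytotoxicity, read by MTT assay, with a stated time of 4 days; on this read-out lower numbers stand for stronger inhibition and higher numbers for weaker inhibition:
compound 1 `C=C1C[C@]23C[C@@]1(O)CC[C@H]2c1ccc(O)c(C)c1[C@@H]3Cn1cc(-c2ccc(C(F)(F)F)cc2)nn1` gives 8950 nM.
compound 2 `C=C1C[C@]23C[C@@]1(O)CC[C@H]2c1cc(Br)c(O)c(C)c1[C@@H]3Cn1cc(-c2ccc(C(F)(F)F)cc2)nn1` gives 7380 nM.
compound 3 `C=C1C[C@]23C[C@@]1(O)CC[C@H]2c1ccc(OS(=O)(=O)c2ccc(C)cc2)c(C)c1[C@@H]3Cn1cc(-c2ccc(C(F)(F)F)cc2)nn1` gives only a limit of the assay, > 20000 nM.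

Compound 1 holds the highest of the two numbers; the step of a 1.2-fold lower number from compound 1 to compound 2 (0.08 log units; within the scatter) stays within the scatter. The step of an at least 2.2-fold higher number from compound 1 to compound 3 (0.34 log units; beyond the scatter) runs to a limit, as the limit of > 20000 nM in this assay, at which 1 of the 3 values shown sits, records, so its true size is open.

Compound 4 `C=C1C[C@]23C[C@@]1(O)CC[C@H]2c1ccc(O)c(C)c1[C@@H]3Cn1cc(-c2ccc(Cl)cc2)nn1` differs from compound 1 by chloro in place of trifluoromethyl on an aromatic carbon. Neither measured step touches the aryl ring on the triazole: both alter the phenol side of the shared core. Among the compounds with values here, no step here therefore bears on this change, and no shift beyond the scatter is expected. Compound 4 is expected near 9000 nM, between 4000 nM and 20000 nM, a step of a 1.0-fold higher number from compound 1 to compound 4 (0.00 log units; within the scatter).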

Compound 4, half-maximal inhibitory concentration: > 20000 nM
Compound 4 was reported as a limit; the forecaster's own chance of this, stated with the estimate: 15%; middle value at least 2.2-fold (0.34 log units) away from the limit.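

In this assay compound 4 gives a limit, not a number: the limit of > 20000 nM in this assay, at which 2 of the 4 values shown sit.

The change from 4-(trifluoromethyl)phenyl to 4-chlorophenyl gives an at least 2.2-fold higher number from compound 1 to compound 4 (0.34 log units; beyond the scatter), so the read-out responds to this position as well as to the phenol side of the shared core. From the compounds shown here alone, the true size of the step remains open.

The compounds shown hold only trifluoromethyl and chloro at this position, so the response to a methoxy, a nitrile or an amine there remains open. Also open, going by these compounds, is whether bromo on the aromatic carbon of compound 2 would hold with chloro in this place.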